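This account rests on a few compounds, and the source may have more. Where it says the series, first, only, none or still open, it means among the compounds named here.

Working notes on the aspirin-nitrate series. Compound 1, structure `O=C(CCCO[N+](=O)[O-])Oc1ccccc1C(=O)O`, compound 2, structure `O=C(CCCCC(CO[N+](=O)[O-])O[N+](=O)[O-])Oc1ccccc1C(=O)O`, and compound 3, structure `CC(C)(CO[N+](=O)[O-])C(=O)Oc1ccccc1C(=O)O`, were tested in a functional assay on aorta (Rattus norvegicus, strain Wistar), in the presence of a further agent that is not named here; on this read-out higher numbers stand for an effect only at larger amounts of compound and lower numbers for an effect already at smaller amounts. In this assay compound 1 gives 23000 nM, compound 2 gives 3100 nM and compound 3 gives 6200 nM. Compound 2 thus carries the lowest number of the three, with compound 3 within the usual scatter of it and compound 1 beyond it. Compound 4, structure `O=C(CCCCCCO[N+](=O)[O-])Oc1ccccc1C(=O)O`, is not yet measured; relative to compound 2 the change is hydrogen in place of nitrooxy on a saturated chain carbon bound to two saturated chain carbons. Within the data shown here, no measured step matches this change. With the nitrooxy removed, a move toward the numbers of compound 1 and compound 3 is expected, so for compound 4 a step of a 2.6-fold higher number from compound 2 to compound 4 (0.41 log units; beyond the scatter) toward weaker effect is estimated, giving an expected 8000 nM with a range from 3000 nM to 25000 nM.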

Compound 4, half-maximal effective concentration: 8100 nM
Estimate against measurement, compound 4: 1.0-fold (0.01 log units) below, and the stated range covers the measured number.
By their numbers in this assay, from the lowest: compounds 2, 3 and 4 (each within the scatter of the next, the first and the last beyond it); then compound 1.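

In this assay hydrogen in place of nitrooxy on a saturated chain carbon bound to two saturated chain carbons gives a 2.6-fold higher number from compound 2 to compound 4 (0.42 log units; beyond the scatter) and so shows that the nitrooxy at this place matters for the number. 3-(nitrooxy)propyl in place of nitrooxy on a saturated chain carbon, three bonds along the chain from a carbonyl carbon, gives a 2.8-fold lower number from compound 1 to compound 4 (0.45 log units; beyond the scatter) and so shows that a single nitrooxy group can go with a lower number when carried on the longer chain. From the compounds shown here alone, whether an amine in place of this nitrooxy, or a still longer chain, would hold the number remains open. No measured property bears on either step.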